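Pyrazole substituent trimming in a glucagon receptor antagonist series

The source may hold more compounds than are shown below. What is called first, only, known or untested is meant among the compounds shown, and "the series" means these compounds.

Measured so far:
compound 1, `CCCC(Oc1ccc(-n2cc(C(F)(F)F)c(C)n2)cc1)c1ccc(C(=O)NCCC(=O)O)cc1`: 8300 nM
compound 2, `CCCC(Nc1cc(C)c(-n2cc(C(F)(F)F)cn2)c(C)c1)c1ccc(C(=O)NCCC(=O)O)cc1`: 1400 nM
compound 3, `CC(C)(C)C(Oc1ccc(-n2cc(C(F)(F)F)cn2)cc1)c1ccc(C(=O)NCCC(=O)O)cc1`: 4300 nM

All three were read in a functional assay on cells for antagonist activity at Glucagon receptor (Homo sapiens), read by cAMP accumulation, in the presence of a further agent that is not named here; on this read-out higher numbers stand for weaker inhibition and lower numbers for stronger inhibition. Compound 1 carries the highest of the three numbers. Its gap to compound 3 lies within the usual scatter, so no order between these two can be read; its gap to compound 2 lies beyond the scatter, so compound 2 is the stronger inhibitor of the pair.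

Compound 4, `CCCC(Oc1ccc(-n2cc(C)cn2)cc1)c1ccc(C(=O)NCCC(=O)O)cc1`, has not yet been measured. It differs from compound 1 in one place: 4-methyl-1H-pyrazol-1-yl in place of 3-methyl-4-(trifluoromethyl)-1H-pyrazol-1-yl on an aromatic carbon. Among the measured compounds shown here, no measured pair in the set isolates this change, so the expectation rests only on the shared core and the position of compound 1. The step from compound 1 to compound 4 is expected to be small and toward a weaker inhibitor, a 1.4-fold higher number from compound 1 to compound 4 (0.16 log units; within the scatter), and may not exceed the scatter. Compound 4 is estimated at 12000 nM, with a range from 4000 nM to 40000 nM.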

Compound 4, antagonist equilibrium constant: 11000 nM
Estimate against measurement, compound 4: 1.1-fold (0.04 log units) above; measured number inside the range.
By their numbers in this assay, from the lowest: compound 2; then compounds 3, 1 and 4 (each within the scatter of the next, the first and the last beyond it).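

Going from 3-methyl-4-(trifluoromethyl)-1H-pyrazol-1-yl to 4-methyl-1H-pyrazol-1-yl, on an aromatic carbon para to a large group, gives a 1.3-fold higher number from compound 1 to compound 4 (0.12 log units; within the scatter) in this assay. Among the compounds shown here, this is the first pair that differs in one place, and it shows that this exchange, which removes the trifluoromethyl group and leaves a single methyl, gives no readable separation between the two compounds. No supporting data bear on this result.

The exchange alters two pyrazole substituents at once, so the contribution of each remains unresolved. Going by these compounds, whether a nitrile, a chlorine or no substituent at all on the pyrazole would read the same also remains open.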